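Ring amine in place of dimethylamino on the shared core

A few compounds are considered here, and "the series" means these few. Any claim that something is new, unique, unknown or untested is made for them only; others in the source may bear on it.

Compound 1 `O=C(CCc1ccc(C(F)(F)F)cc1)Nc1ccc2nc(N3CC4CC3CN4)ccc2c1` gives 490 nM in a functional assay on HEK293 cells for activation of melanin-concentrating hormone receptor 1 (Rattus norvegicus), read by inositol phosphate accumulation; on this read-out higher numbers stand for an effect only at larger amounts of compound and lower numbers for an effect already at smaller amounts. Compound 2 `CC1CCCN1c1ccc2cc(NC(=O)CCc3ccc(C(F)(F)F)cc3)ccc2n1` gives 270 nM, and compound 3 `CN(C)c1ccc2cc(NC(=O)CCc3ccc(C(F)(F)F)cc3)ccc2n1` gives 110 nM, the lowest of the three numbers: the step of a 2.5-fold lower number from compound 2 to compound 3 (0.39 log units; beyond the scatter) and the step of a 4.5-fold lower number from compound 1 to compound 3 (0.65 log units; beyond the scatter) both lie beyond the scatter, whereas the step of a 1.8-fold lower number from compound 1 to compound 2 (0.26 log units; within the scatter) does not. Compound 4 `NC1CCN(c2ccc3cc(NC(=O)CCc4ccc(C(F)(F)F)cc4)ccc3n2)C1` carries 3-aminopyrrolidin-1-yl in place of dimethylamino on an aromatic carbon. The two ring amines measured so far, in compound 1 and compound 2, gave higher numbers than the acyclic amine of compound 3, so a return to a five-membered ring amine is expected to raise the number modestly in this assay. The expected step is a 2.3-fold higher number from compound 3 to compound 4 (0.36 log units; beyond the scatter). Compound 4 is therefore estimated at 250 nM, with a range from 80 nM to 800 nM.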

Compound 4, half-maximal effective concentration: 200 nM
Compound 4: the middle estimate sits 1.3-fold (0.10 log units) above what was measured, within the range that was stated.
By their numbers in this assay, from the lowest: compounds 3, 4, 2 and 1 (each within the scatter of the next, the first and the last beyond it).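

In this assay, within the data shown here, 3-aminopyrrolidin-1-yl is the first ring amine at this position that cannot be told apart from dimethylamino (a 1.8-fold higher number from compound 3 to compound 4 (0.26 log units; within the scatter)). It also stays within the scatter of 2-methylpyrrolidin-1-yl (a 1.4-fold lower number from compound 2 to compound 4 (0.13 log units; within the scatter)), whereas the gap to the two-ring group is beyond it (a 2.5-fold lower number from compound 1 to compound 4 (0.39 log units; beyond the scatter)). A ring with an added hydrogen-bond donor is therefore tolerated here, within these four compounds.

Unsubstituted pyrrolidin-1-yl or 3-hydroxypyrrolidin-1-yl on the shared core would show whether the amino group contributes at all. No measurement shown here bears on the cause of these steps.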